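The compounds below may be only part of what the source reports. "The series", "measured", "known", "first", "only" and "open" are said of these compounds alone.

Compound 3, `O=S(=O)(c1cccc(F)c1)c1cnc2c(F)cccc2c1-c1ccc(Cl)cc1`, sits at the low end of the set: in an ADME assay on microsomes from liver (Homo sapiens) for metabolic stability, tested at 2.5 uM (a lower number here means slower removal, a higher number faster removal of the compound), compound 3 gives 0.62 mL/min, which is the lowest of the three numbers, beyond the scatter from both of the others. Its nearest neighbour is compound 2, `COc1ccc(-c2c(S(=O)(=O)c3ccc(OC)cc3)cnc3c(F)cccc23)cc1`, which in this assay gives 2.12 mL/min, and the furthest is compound 1, `COc1ccc(-c2c(S(=O)(=O)c3ccc(C)c(F)c3)cnc3c(F)cccc23)cc1`, which in this assay gives 3.27 mL/min. Among the measured compounds shown here, the one single-point step measured so far, a 1.5-fold lower number from compound 1 to compound 2 (0.19 log units; within the scatter), concerns a change on the sulfonyl sulfur and stays within the scatter.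

Compound 4, `COc1ccc(-c2c(S(=O)(=O)c3cccc(F)c3)cnc3c(F)cccc23)cc1`, differs from compound 3 by methoxy in place of chloro on an aromatic carbon, the group sitting para to a large group. For the measured compounds named here, no measured step covers this exchange. Compounds 1 and 2 both carry a 4-methoxyphenyl and both sit well above compound 3, but they also differ from it on the sulfonyl sulfur, so their values are only a loose guide. A moderate rise is therefore expected, a 1.9-fold higher number from compound 3 to compound 4 (0.29 log units; within the scatter), with the estimate for compound 4 in this assay placed at 1.2 mL/min, within a range of 0.5 mL/min to 3 mL/min.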

Compound 4, intrinsic clearance in a liver preparation (reported as CLH), per the amount of preparation that the assay uses: 2.48 mL/min
Estimate against measurement, compound 4: 2.1-fold (0.32 log units) below, within the range that was stated.
By their numbers in this assay, from the lowest: compound 3; then compounds 2, 4 and 1 (each within the scatter of the next).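

Among the compounds shown here, the exchange of chloro for methoxy para to a large group gives the first direct single-change reading at this position: a 4.0-fold higher number from compound 3 to compound 4 (0.60 log units; beyond the scatter) in this assay. By contrast, the two changes elsewhere that keep the 4-methoxyphenyl in place, a 1.2-fold higher number from compound 2 to compound 4 (0.07 log units; within the scatter) and a 1.3-fold lower number from compound 1 to compound 4 (0.12 log units; within the scatter), both stay within the scatter, so among these compounds only the move from 4-chlorophenyl to 4-methoxyphenyl shifts the number beyond it.

Chloro appears only in compound 3, so whether the exchange reads the same with another group on the sulfonyl sulfur remains open. Also open, going by these compounds, is how an amine or a carboxylic acid at this place would compare with chloro and methoxy. Nothing shown here offers any measurement that accounts for the size of this step.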